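The source may hold more compounds than are shown below. What is called first, only, known or untested is meant among the compounds shown, and "the series" means these compounds.

Measured so far in a physicochemical assay for solubility, using the shake flask method, in simulated intestinal fluid, measured as kinetic solubility, with a stated time of 2 h, at 25 degrees C, at pH 6.5; on this read-out higher numbers stand for higher solubility and lower numbers for lower solubility:
- compound 1, `CCCOC(=O)c1nc(C)c2c(c1N)C(=O)N(Cc1ccccc1)C2=O`: < 5000 nM
- compound 2, `Cc1nnc(-c2nc(C)c3c(c2N)C(=O)N(Cc2ccccc2)C3=O)o1`: < 5000 nM
- compound 3, `Cc1noc(-c2nc(C)c3c(c2N)C(=O)N(CC2CCOCC2)C3=O)n1`: 5700 nM
- compound 4, `Cc1noc(-c2nc(C)c3c(c2N)C(=O)N(Cc2ccc(OC(F)F)cc2)C3=O)n1`: not yet measured

The value of compound 1, < 5000 nM, is a limit of this assay and not a number. The value of compound 2, < 5000 nM, is likewise a limit. Only compound 3 gives an actual number, 5700 nM, so compound 3 is the sole point of reference on this read-out; the other two values sit at the limit of < 5000 nM in this assay, at which 2 of the 3 values shown sit. Within the data shown here, the one step between measured compounds, a step that the two limits leave unreadable from compound 1 to compound 2, is unreadable because both ends are limits.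

Compound 4 differs from compound 3 as follows: 4-(difluoromethoxy)phenyl in place of oxan-4-yl on a saturated chain carbon bound to an amide-type nitrogen in a ring. Among the measured compounds shown here, no measured step changes the group on the saturated chain carbon bound to the amide-type nitrogen in the ring, so nothing measured bears directly on this change, and the expectation rests on the value of compound 3 alone. Compound 4 is expected to give roughly 2500 nM, with a range from 700 nM to 7000 nM. That estimate means an expected step of a 2.3-fold lower number from compound 3 to compound 4 (0.36 log units; beyond the scatter), with a fair chance that this assay returns only a limit for compound 4.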

Compound 4, solubility: < 5000 nM
Compound 4 ended at the assay's limit (the forecaster's own chance of this, stated with the estimate: 60%); the middle value does not contradict the limit.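

Among these compounds, this is the only measured change on the saturated chain carbon bound to an amide-type nitrogen in a ring, and in this assay putting 4-(difluoromethoxy)phenyl in place of oxan-4-yl gives an at least 1.1-fold lower number from compound 3 to compound 4 (0.05 log units; that floor lies within the scatter). The value of compound 4 is a limit of the assay and not a number, so the step has only a floor, and a floor within the scatter does not by itself establish a real difference at this position. Compound 3 remains the only compound with an actual number, and the limit now holds most of the series: the limit of < 5000 nM in this assay, at which 3 of the 4 values shown sit.

Among the compounds shown here, the one earlier step, which runs between two limits, cannot be read, so the effect of the group on the aromatic carbon stays unknown, as does how far the true value of compound 4 lies from the limit. From the compounds shown here alone, it also remains open whether an amine or a carboxylic acid in place of oxan-4-yl would give a number on this read-out, and whether a plain phenyl would behave like 4-(difluoromethoxy)phenyl.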